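The source may report more compounds than this note shows. Statements on the series, on what has been measured and on what is new or still open speak of the compounds shown alone.

Measured compounds:
compound 1 `O=C(CSc1nc(Nc2ccccc2)c2ccccc2n1)Nc1ccccc1Cl` — 9610 nM
compound 2 `O=C(CSc1nc(Nc2ccccc2)c2ccccc2n1)Nc1cccc(Br)c1` — 10100 nM

In a functional assay on NCI-H1975 cells (Homo sapiens) for inhibition, read by MTT assay, with a stated time of 72 h (on this read-out lower numbers stand for stronger inhibition and higher numbers for weaker inhibition), compound 1 gives 9610 nM. Among the measured compounds shown here, its only neighbour in the data is compound 2, which gives 10100 nM; compound 1 has the smaller of the two numbers, but the step of a 1.1-fold higher number from compound 1 to compound 2 (0.02 log units; within the scatter) lies within the scatter, so the two compounds cannot be told apart on this read-out. The unmeasured compound 3 `O=C(CSc1nc(Nc2ccccc2)c2ccccc2n1)Nc1ccc(Cl)c(Cl)c1` differs from compound 1 in one place, on the amide-type nitrogen: 3,4-dichlorophenyl in place of 2-chlorophenyl on an amide-type nitrogen. For the measured compounds named here, the single measured step that bears on this change is a 1.1-fold higher number from compound 1 to compound 2 (0.02 log units; within the scatter), in which a differently halogenated phenyl replaced the 2-chlorophenyl on the same amide-type nitrogen without moving the number beyond the scatter. On that basis no step beyond the scatter is expected in this assay from compound 1 to compound 3, and the estimated step is a 1.2-fold lower number from compound 1 to compound 3 (0.08 log units; within the scatter). Compound 3 is therefore expected to give 8000 nM, with a range from 3000 nM to 20000 nM.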

Compound 3, half-maximal inhibitory concentration: 10400 nM
For compound 3 the middle estimate is 1.3-fold (0.11 log units) below the measured one; the measured number falls inside the stated range.
By their numbers in this assay, from the lowest: compounds 1, 2 and 3 (each within the scatter of the next).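

In this assay the 3,4-dichlorophenyl group of compound 3 stands on the amide-type nitrogen with no step beyond the scatter against either earlier group (a 1.1-fold higher number from compound 1 to compound 3 (0.03 log units; within the scatter); a 1.0-fold higher number from compound 2 to compound 3 (0.01 log units; within the scatter)). The earlier pair had shown only one singly halogenated phenyl group exchanged for another, whereas compound 3 carries a second chlorine on the ring. The number still does not separate from those of the two singly halogenated compounds, so compounds 1, 2 and 3 cannot be told apart on this read-out, and among these three groups neither the number of halogens nor the kind and place of halogen shows any effect.

Going by these compounds, all three groups on this nitrogen are halogenated phenyl rings, so it remains open whether an unsubstituted phenyl, a methoxyphenyl, a carboxylic acid on the ring, a pyridine in place of the phenyl or a simple alkyl chain would give a step beyond the scatter. On these data alone, it is also open whether any change elsewhere on the shared core would move the number at all. Nothing measured here offers an explanation for these results.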